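The compounds below may be only part of what the source reports. "The series", "measured", "known", "first", "only" and "open" are said of these compounds alone.

Compound 1 `Cc1nn([C@H](C)c2ccc(Cl)cc2Cl)c2nc(N3CC[C@H](N4CCCC4)[C@H](C)C3)cnc12` — "not determined" (no result reported) in an assay on CCRF-CEM cells for antagonist activity at C-C chemokine receptor type 4 (Homo sapiens), read by CellTiter-Glo, with stated times of 30 min and 60 min, in the presence of a further agent that is not named here; a higher number here means a weaker inhibitor, a lower number a stronger inhibitor
Compound 2 `Cc1nn([C@H](C)c2ccc(Cl)cc2Cl)c2nc(N3CC[C@H](N4CCCCC4)[C@H](C)C3)cnc12` — 361 nM

Compound 1 gives "not determined" (no result reported) in this assay, so its place cannot be given. Among the measured compounds shown here, the group on the saturated ring carbon is the only place where compound 1 and compound 2 differ; in this assay compound 2 gives 361 nM. Compound 3 `Cc1nn([C@H](C)c2ccc(Cl)cc2Cl)c2nc(N3CC[C@H](N4CCCCCC4)[C@H](C)C3)cnc12` differs from compound 1 by azepan-1-yl in place of pyrrolidin-1-yl on a saturated ring carbon. With no value for compound 1, neither the size nor the direction of this step can be read from the data. Resting on compound 2 alone, compound 3 is expected to give about 500 nM in this assay, estimated between 150 nM and 1800 nM.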

Compound 3, half-maximal inhibitory concentration: 195 nM
For compound 3 the middle estimate is 2.6-fold (0.41 log units) above the measured one; the measured number falls inside the stated range.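

In this assay, among the compounds shown here, the one readable step at this position is a 1.9-fold lower number from compound 2 to compound 3 (0.27 log units; within the scatter), so azepan-1-yl and piperidin-1-yl on this saturated ring carbon are not told apart. Activity therefore persists with the seven-membered ring in place of the six-membered one. The steps from compound 1 cannot be read, which leaves pyrrolidin-1-yl unplaced, and no evidence here explains the result. Still open, on these data alone, is whether morpholin-4-yl, with a second ring hetero atom, or an open-chain diethylamino group would keep this activity on the same carbon.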